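A few compounds are considered here, and "the series" means these few. Any claim that something is new, unique, unknown or untested is made for them only; others in the source may bear on it.

Of the compounds shown here, three built on the same core have been measured in a functional assay for inhibition of sodium/hydrogen exchanger (Oryctolagus cuniculus); on this read-out higher numbers stand for weaker inhibition and lower numbers for stronger inhibition. Compound 1 `Cc1cc(-c2ccc(Cl)cc2Cl)c(S(C)(=O)=O)cc1C(=O)N=C(N)N` gives 42 nM. Compound 2 `CSc1cc(C)c(C(=O)N=C(N)N)cc1S(C)(=O)=O` gives 6 nM. Compound 3 `Cc1cc(OCc2ccccc2)c(S(C)(=O)=O)cc1C(=O)N=C(N)N` gives 28 nM. Of these three numbers, compound 3 has the second highest; the step of a 1.5-fold lower number from compound 1 to compound 3 (0.18 log units; within the scatter) lies within the scatter, whereas the step of a 4.7-fold higher number from compound 2 to compound 3 (0.67 log units; beyond the scatter) lies beyond it.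

Compound 4 `Cc1cc(N2CCC(N)CC2)c(S(C)(=O)=O)cc1C(=O)N=C(N)N` has not yet been measured. It differs from compound 3 in one place: 4-aminopiperidin-1-yl in place of benzyloxy on an aromatic carbon. All three measured steps concern this same aromatic carbon: a 7.0-fold lower number from compound 1 to compound 2 (0.85 log units; beyond the scatter), a 1.5-fold lower number from compound 1 to compound 3 (0.18 log units; within the scatter) and a 4.7-fold higher number from compound 2 to compound 3 (0.67 log units; beyond the scatter). The smallest group, methylsulfanyl, went with the lowest number, while the two larger groups, 2,4-dichlorophenyl and benzyloxy, gave numbers within the scatter of each other. Among the measured compounds shown here, the 4-aminopiperidin-1-yl group resembles neither closely, and no measured compound carries a ring with a hetero atom or a hydrogen-bond donor at this position, so the direction is uncertain. The expected step is therefore modest, a 1.4-fold lower number from compound 3 to compound 4 (0.15 log units; within the scatter), with a wide range to either side. For compound 4 the estimated value in this assay is 20 nM, expected to fall between 5 nM and 80 nM.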

Compound 4, half-maximal inhibitory concentration: 9.8 nM
For compound 4 the middle estimate is 2.0-fold (0.31 log units) above the measured one; measured number inside the range.
By their numbers in this assay, from the lowest: compounds 2 and 4 (each within the scatter of the next); then compounds 3 and 1 (each within the scatter of the next).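

In this assay, this aromatic carbon, ortho to a methylsulfonyl group, now carries a non-aromatic ring with a hetero atom and a hydrogen-bond donor, and the number falls clearly both against benzyloxy (a 2.9-fold lower number from compound 3 to compound 4 (0.46 log units; beyond the scatter)) and against 2,4-dichlorophenyl (a 4.3-fold lower number from compound 1 to compound 4 (0.63 log units; beyond the scatter)). Against methylsulfanyl, the smallest of the groups, no difference can be claimed (a 1.6-fold higher number from compound 2 to compound 4 (0.21 log units; within the scatter)), so compound 4 goes against the link between the smallest group and the lowest number that compounds 1, 2 and 3 suggested: here a much larger group does as well as the small one. No measurement at hand explains why this exchange lowers the number.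

The compounds shown do not separate the ring of compound 4 from the amino group it carries, and a plain piperidin-1-yl group or an open-chain aminoethylamino group at this carbon would pull those two apart. They also leave open whether a nitrogen is needed on that ring at all, which a hydroxyl or a carboxylic acid in place of the amino group would test.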